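The source may hold more compounds than are shown below. What is called first, only, known or untested is meant among the compounds shown, and "the series" means these compounds.

Compound 1 `O=S(=O)(CCCN1CCc2cc(OCc3ccccc3)ccc2C(O)C1)c1ccccc1` gives 349 nM in an assay for displacement of a labelled ligand from Sigma non-opioid intracellular receptor 1 (Cavia porcellus), read by scintillation counting, with a stated time of 180 min; a higher number here means a weaker inhibitor, a lower number a stronger inhibitor. Compound 2 `CC1(C)COC(CCCN2CCc3cc(OCc4ccccc4)ccc3C(O)C2)(c2ccc(C(C)(C)C)cc2)OC1` reaches only a limit of > 1000 nM in this assay, and its value therefore sits at the limit of > 1000 nM in this assay, at which 1 of the 2 values shown sits. Compound 3 `COc1ccc(C2(CCCN3CCc4cc(OCc5ccccc5)ccc4C(O)C3)OCC(C)(C)CO2)cc1` differs from compound 2 by methoxy in place of tert-butyl on an aromatic carbon. Since compound 2 is known only as a limit, the step between the two cannot be anchored to a number, and compound 3 is expected to remain near that limit, so the expected step that the limit leaves unreadable from compound 2 to compound 3 is taken as none beyond the usual scatter. Compound 3 is estimated at 2000 nM in this assay, within a range from 500 nM to 8000 nM.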

Compound 3, inhibition constant: > 1000 nM
Compound 3: a limit, no number (the forecaster's own chance of this, stated with the estimate: 60%); the middle value does not contradict the limit.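

Among these compounds, compound 2 and compound 3 are both known only as limits in this assay, so no step between them can be read. The compounds shown leave open how far methoxy in place of tert-butyl shifts the inhibition constant, if at all.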